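Fluorines in place of chlorine on a benzyl arm

The source may hold more compounds than are shown below. What is called first, only, known or untested is meant among the compounds shown, and "the series" means these compounds.

Four compounds share one core and differ only in the ring carried on the benzyl arm. Compound 1 `O=C(C[C@]1(O)CC[C@@H](Cc2ccccc2)CC1)Nc1ccc2[nH]c(=O)oc2c1` carries a plain phenyl ring, compound 2 `O=C(C[C@]1(O)CC[C@H](Cc2ccc(F)cc2)CC1)Nc1ccc2[nH]c(=O)oc2c1` a 4-fluorophenyl ring, compound 3 `O=C(C[C@]1(O)CC[C@@H](Cc2ccc(Cl)cc2)CC1)Nc1ccc2[nH]c(=O)oc2c1` a 4-chlorophenyl ring, and compound 4 `O=C(C[C@]1(O)CC[C@@H](Cc2ccc(F)c(F)c2)CC1)Nc1ccc2[nH]c(=O)oc2c1` a 3,4-difluorophenyl ring.

In an ADME assay on the whole organism (strain Sprague-Dawley) for pharmacokinetics, with Rattus norvegicus as the target, using cassette dosing (on this read-out lower numbers stand for slow clearance and higher numbers for fast clearance), compound 1 gives 34.1 mL/min/kg and compound 2 gives 42.3 mL/min/kg; these two numbers lie within the scatter of each other. In this assay compound 3 stands as "not determined" (no result reported), so its place on the scale is open.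

The change from compound 3 to compound 4 is 3,4-difluorophenyl in place of 4-chlorophenyl on a saturated chain carbon bound to a saturated ring carbon. Within the data shown here, with no measured step between compounds of this kind to lean on, the expectation is that this change moves this assay by no more than the scatter, in no fixed direction.

Resting on the values of compound 1 34.1 mL/min/kg and compound 2 42.3 mL/min/kg, compound 4 is expected to give about 40 mL/min/kg in this assay, within a range from 20 mL/min/kg to 75 mL/min/kg.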

Compound 4, clearance: 35.7 mL/min/kg
Compound 4: the middle estimate sits 1.1-fold (0.05 log units) above what was measured; the range from low to high includes it.
By their numbers in this assay, from the lowest: compounds 1, 4 and 2 (each within the scatter of the next).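

In this assay, among these compounds, the change to 3,4-difluorophenyl in place of phenyl, on a saturated chain carbon bound to a saturated ring carbon, comes with a 1.0-fold higher number from compound 1 to compound 4 (0.02 log units; within the scatter) and gives the first measured step at this position. It shows that this ring can carry two fluorines while clearance stays within the scatter of the plain phenyl compound. No measurement here accounts for this result.

The change from 4-chlorophenyl to 3,4-difluorophenyl cannot be read, as compound 3 has no number to compare with compound 4. Also open, from the compounds shown here alone, is whether a different group on this ring, such as an amine or a carboxylic acid, would move clearance beyond the scatter.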